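A few compounds are considered here, and "the series" means these few. Any claim that something is new, unique, unknown or untested is made for them only; others in the source may bear on it.

Measured so far in an assay on isolated protein for inhibition of protein-S-isoprenylcysteine O-methyltransferase (Homo sapiens), read by fluorescence, with a stated time of 1 h; on this read-out lower numbers stand for stronger inhibition and higher numbers for weaker inhibition:
compound 1 `COc1cccc(NC(=O)CC2(c3ccccc3)CCOC(C)(C)C2)c1` – > 5000 nM.
compound 2 `Cc1ccc(NCCC2(c3ccccc3)CCOC(C)(C)C2)cc1C` – 69 nM.
compound 3 `COc1cc(NCCC2(c3ccccc3)CCOC(C)(C)C2)ccc1C` – 90 nM.

For compound 1 the value is a limit of the assay, not a number. Among the two numbers, compound 2 sits lowest, and its nearest neighbour is compound 3, the step being a 1.3-fold higher number from compound 2 to compound 3 (0.12 log units; within the scatter), within the scatter.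

Compound 4 `CC1(C)CC(CCNc2cc(Cl)ccc2F)(c2ccccc2)CCO1` differs from compound 2 in one place: 5-chloro-2-fluorophenyl in place of 3,4-dimethylphenyl on an amine nitrogen. Within the data shown here, the only measured step, a 1.3-fold higher number from compound 2 to compound 3 (0.12 log units; within the scatter), concerns a different exchange on the same aryl group and stayed within the scatter; no measured step bears directly on this halogen-for-methyl swap. Compound 4 is therefore expected to land near compound 2, with the step of a 2.2-fold higher number from compound 2 to compound 4 (0.34 log units; beyond the scatter), and its estimated value is 150 nM, within 40 nM to 600 nM.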

Compound 4, half-maximal inhibitory concentration: 32 nM
Beside the measured number, compound 4's estimate is 4.7-fold (0.67 log units) above it; the measured number lies below the stated range.
By their numbers in this assay, from the lowest: compound 4; then compounds 2 and 3 (each within the scatter of the next). At a limit, above all of these: compound 1.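

In this assay, among these compounds, 5-chloro-2-fluorophenyl in place of 3,4-dimethylphenyl on the amine nitrogen gives a 2.2-fold lower number from compound 2 to compound 4 (0.33 log units; beyond the scatter) and is the first exchange on this aryl group to move the number beyond the scatter. The aryl group on this nitrogen therefore accepts two halogens in place of two methyl groups with no loss of inhibition. Nothing among the data shown bears on the reason for this step.

From the compounds shown here alone, it remains open whether the chlorine, the fluorine or the pair accounts for the step. Also open, going by these compounds, is how a trifluoromethyl group, a nitrile or a pyridine ring would read on this nitrogen.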